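Replacing the Trifluoromethylphenylamino Group with Piperidinyl

The source may report more compounds than this note shows. Statements on the series, on what has been measured and on what is new or still open speak of the compounds shown alone.

Three compounds built on the core of compound 1 `O=C(O)CCC(=O)OCCCCCCSc1ccc([N+](=O)[O-])c2nonc12` have been measured in an assay on isolated protein for inhibition of glutathione S-transferase Mu 2 (Homo sapiens), with a stated time of 10 min; a lower number here means a stronger inhibitor, a higher number a weaker inhibitor. Compound 1 gives 160 nM. Compound 2 `O=C(CCC(=O)OCCCCCCSc1ccc([N+](=O)[O-])c2nonc12)Nc1ccccc1` gives 700 nM, and compound 3 `O=C(CCC(=O)OCCCCCCSc1ccc([N+](=O)[O-])c2nonc12)Nc1ccc(C(F)(F)F)cc1` gives 90 nM. Compound 3 thus carries the lowest of the three numbers; the step of a 1.8-fold lower number from compound 1 to compound 3 (0.25 log units; within the scatter) is within the scatter, while the step of a 7.8-fold lower number from compound 2 to compound 3 (0.89 log units; beyond the scatter) lies beyond it, so compound 3 can only be called separated from compound 2, not from compound 1.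

Compound 4 `O=C(CCC(=O)N1CCCCC1)OCCCCCCSc1ccc([N+](=O)[O-])c2nonc12` differs from compound 3 in one place: piperidin-1-yl in place of (4-(trifluoromethyl)phenyl)amino on a carbonyl carbon. Among the compounds with values here, no measured step exchanges an aromatic amine for a saturated ring amine at this carbonyl carbon, so the expectation rests on neighbouring steps. The step of a 4.4-fold higher number from compound 1 to compound 2 (0.64 log units; beyond the scatter) shows that the group on this carbonyl carbon moves the number modestly, and the step of a 7.8-fold lower number from compound 2 to compound 3 (0.89 log units; beyond the scatter) shows that the trifluoromethyl on the aromatic ring is responsible for much of the lower number of compound 3. Compound 4 keeps neither the aromatic ring nor the trifluoromethyl, and its number is therefore expected to rise, by roughly a 4.4-fold higher number from compound 3 to compound 4 (0.65 log units; beyond the scatter). Compound 4 is estimated at 400 nM, within 120 nM to 1500 nM.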

Compound 4, half-maximal inhibitory concentration: 110 nM
The estimate for compound 4 lay 3.6-fold (0.56 log units) above the measured number; the whole stated range lies above it.
By their numbers in this assay, from the lowest: compounds 3, 4 and 1 (each within the scatter of the next); then compound 2.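

In this assay, the exchange on this carbonyl carbon gives a 1.2-fold higher number from compound 3 to compound 4 (0.09 log units; within the scatter), so for this pair, a number in this range needs neither the aromatic ring nor the amide hydrogen, and a non-aromatic ring with no trifluoromethyl serves as well. Within the data shown here, the piperidin-1-yl group also gives a 6.4-fold lower number from compound 2 to compound 4 (0.80 log units; beyond the scatter), whereas the step of a 1.5-fold lower number from compound 1 to compound 4 (0.16 log units; within the scatter) leaves it level with the free carboxylic acid, so of the four groups tried on this carbonyl carbon, only anilino stands apart, and the trifluoromethyl is not the only change that separates a compound from it. Nothing given here explains why two such different groups give numbers within the scatter of each other.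

The compounds shown leave open whether other saturated ring amines, such as pyrrolidine or morpholine, or an open-chain amine such as dimethylamine, would also stay in this range. They also leave open whether a chlorine or methoxy group in place of the trifluoromethyl would restore the number of an anilide, and whether any of this holds with a shorter or longer chain.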